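Chloro added to the core of compound 3

The source may report more compounds than this note shows. Statements on the series, on what has been measured and on what is new or still open speak of the compounds shown alone.

Compound 3 `O=c1cc(CSC(=S)N2CCCCC2)oc2ccccc12` is known in a functional assay on MDA-MB-435S cells (Homo sapiens) for antiproliferative activity, read by MTT assay, with a stated time of 72 h (on this read-out higher numbers stand for weaker inhibition and lower numbers for stronger inhibition), only by a limit, > 25000 nM, so its standing among the numbers shown is a floor rather than a point, and one further value shown is likewise a limit (the limit of > 25000 nM in this assay, at which 1 of the 3 values shown sits). Compound 1 `O=c1cc(CSC(=S)N2CCCCC2)oc2cc(Cl)ccc12` gives 3000 nM in this assay. Compound 2 `O=c1cc(CSC(=S)N2CCCC2)oc2ccccc12` is also reported only as a limit, > 30000 nM (the limit of > 30000 nM in this assay, at which 1 of the 3 values shown sits). Of the measured steps, an at least 8.3-fold higher number from compound 1 to compound 3 (0.92 log units; beyond the scatter) bears most directly on the present change, since it removes a chloro from an aromatic carbon, though on a different ring. The other step, a step that the two limits leave unreadable from compound 2 to compound 3, gives no readable size. Compound 4 `O=c1c(Cl)c(CSC(=S)N2CCCCC2)oc2ccccc12` carries chloro in place of hydrogen on an aromatic carbon. The loss of chloro in the step from compound 1 to compound 3 cost potency, so restoring a chloro, even at another carbon, is expected to move the number downward, modestly and with wide uncertainty, an at least 2.0-fold lower number from compound 3 to compound 4 (0.31 log units; beyond the scatter). Compound 4 is therefore estimated at 12000 nM, between 2500 nM and 60000 nM, in this assay.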

Compound 4, half-maximal inhibitory concentration: 770 nM
Estimate against measurement, compound 4: 16-fold (1.19 log units) above; measured number outside the range, below it.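

In this assay, a single chloro on this aromatic carbon, two atoms from the ring oxygen, gives an at least 32-fold lower number from compound 3 to compound 4 (1.51 log units; beyond the scatter), so this position on its own responds strongly to the change. For the compounds shown here, the only earlier readable chloro step, an at least 8.3-fold higher number from compound 1 to compound 3 (0.92 log units; beyond the scatter), lay on the other ring of the shared core and said nothing about the ring with the oxygen. The new step is a floor and not a point, as compound 3 is known only as a limit: the limit of > 25000 nM in this assay, at which 1 of the 4 values shown sits.

The compounds shown leave open whether a bromo, a methyl or an amine on this same carbon would act as chloro does. They also leave open whether the chloro step holds with the pyrrolidin-1-yl group of compound 2, or with a second chloro on the other ring.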